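The source may hold more compounds than are shown below. What is called first, only, known or untested is meant among the compounds shown, and "the series" means these compounds.

Compound 3 `COc1ccc(COCC(Cn2ccnc2)OCc2ccc(C(=O)OCc3ccccc3)cc2)cc1` gives the highest number among the three measured compounds in a functional assay for inhibition of Thromboxane-A synthase (Homo sapiens) (on this read-out higher numbers stand for weaker inhibition and lower numbers for stronger inhibition), at 1490 nM. Compound 1 `COC(=O)c1ccc(COC(COCc2ccc(OC)cc2)Cn2ccnc2)cc1` stands nearest to it, with 1260 nM in this assay, a gap that lies within the scatter. Compound 2 `CCCCOC(=O)c1ccc(COC(COCc2ccc(OC)cc2)Cn2ccnc2)cc1` stands furthest from it, at 200 nM. The step to compound 4 `CCCCCCCCOC(=O)c1ccc(COC(COCc2ccc(OC)cc2)Cn2ccnc2)cc1` is heptyl in place of phenyl on a saturated chain carbon bound to an oxygen next to a carbonyl group. Among the compounds with values here, three measured steps bear on this change at the same place. a 6.3-fold lower number from compound 1 to compound 2 (0.80 log units; beyond the scatter) shows that a longer chain ester strengthened inhibition. a 1.2-fold higher number from compound 1 to compound 3 (0.07 log units; within the scatter) shows that the phenyl at this place stayed within the scatter, and a 7.5-fold higher number from compound 2 to compound 3 (0.87 log units; beyond the scatter) shows the benzyl ester as the weaker of the two. Within the data shown here, a heptyl reaches further than propyl and carries no ring, so a move towards the number of compound 2 is expected, although an octyl ester has no direct precedent here and the size of the step is uncertain. Compound 4 is therefore expected to give 300 nM, within a range from 80 nM to 1200 nM. This expected change amounts to a 5.0-fold lower number from compound 3 to compound 4 (0.70 log units; beyond the scatter).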

Compound 4, half-maximal inhibitory concentration: 21000 nM
Compound 4: middle estimate off by 70-fold (1.85 log units), on the low side; the whole stated range lies below it.
By their numbers in this assay, from the lowest: compound 2; then compounds 1 and 3 (each within the scatter of the next); then compound 4.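

In this assay the gain from lengthening the ester chain does not continue: a 110-fold higher number from compound 2 to compound 4 (2.02 log units; beyond the scatter) reverses the earlier improvement and more. The octyloxycarbonyl compound also falls behind both other esters, with a 14-fold higher number from compound 3 to compound 4 (1.15 log units; beyond the scatter) against the benzyloxycarbonyl compound and a 17-fold higher number from compound 1 to compound 4 (1.22 log units; beyond the scatter) against the methyl ester, so compound 4 is the weakest inhibitor of the four. Across compounds 1, 2 and 4, this position therefore responds to chain length in a rise and fall rather than a steady trend, and a heptyl here costs far more than a phenyl. Nothing available explains this reversal. Where between the butyl and octyl esters the loss sets in remains open, as does how a pentyl or hexyl ester, a branched chain or a free carboxylic acid would behave at this place.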